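A few compounds are considered here, and "the series" means these few. Any claim that something is new, unique, unknown or untested is made for them only; others in the source may bear on it.

Three compounds share one core. In a functional assay on HUVEC cells (Homo sapiens), read by fluorescence and microscopy, with a stated time of 6 h, tested at 10 uM (on this read-out lower numbers stand for a stronger effect and higher numbers for a weaker effect at the one concentration tested), compound 1 `COc1cccc(Nc2sc3ccccc3c2C#N)c1` gives 81%, compound 2 `N#Cc1c(Nc2ccccc2)sc2ccccc12` gives 81%, and compound 3 `N#Cc1c(Nc2ccccc2O)sc2ccccc12` gives 19%. Compound 2 thus stands level with compound 1, the pair together the highest of the three, and far from compound 3. Removing a methoxy gave no change at the digits printed from compound 1 to compound 2 (within the scatter), while adding a hydroxy gave a number 62 percentage points lower from compound 2 to compound 3 (beyond the scatter). Compound 4 `N#Cc1c(Nc2ccc(C(F)(F)F)cc2)sc2ccccc12` arises from compound 2 by trifluoromethyl in place of hydrogen on an aromatic carbon. Trifluoromethyl carries no hydrogen-bond donors or acceptors, unlike hydroxy, so the large drop to compound 3 bears only loosely, while the unchanged methoxy step shows a substituent on this ring need not shift the number. A modest expected step is a number 13 percentage points lower from compound 2 to compound 4 (beyond the scatter). Compound 4 is therefore estimated at 68%, between 35% and 95%.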

Compound 4, a percentage reported as activity, at one concentration (the size of the read-out at that concentration, not a potency): 24%
Beside the measured number, compound 4's estimate is 44 percentage points above it; measured number below the stated range.
By their numbers in this assay, from the lowest: compounds 3 and 4 (each within the scatter of the next); then compounds 1 and 2 (each within the scatter of the next).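

In this assay, trifluoromethyl para to a large group gives a number 57 percentage points lower from compound 2 to compound 4 (beyond the scatter), so a large step on this ring does not require a hydroxy: the entering group has 0 hydrogen-bond donors and 0 hydrogen-bond acceptors. Together with the methoxy result, this shows that a substituent on this ring may leave the number unchanged or move it greatly. No measured evidence here explains this step. The compounds shown leave open how a methyl, a chlorine or an amine would read at this same place. They also leave open whether trifluoromethyl elsewhere on this ring would give a similar step.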